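From methyl to amino: compound 2 to compound 3

The compounds below may be only part of what the source reports. "The series", "measured", "known", "first", "only" and "open" are said of these compounds alone.

Measured so far in a functional assay on A2780 cells (Homo sapiens) for antiproliferative activity, read by MTT assay, with a stated time of 48 h; on this read-out lower numbers stand for stronger inhibition and higher numbers for weaker inhibition:
- compound 1 `CCOc1ccc(-c2cc3c(cn2)[nH]c(=O)n3-c2cc(OC)c(OC)c(OC)c2)cc1F` gives 4330 nM
- compound 2 `COc1ccc(-c2cc3c(cn2)[nH]c(=O)n3-c2cc(OC)c(OC)c(OC)c2)cc1C` gives 1530 nM

Of these two measurements, compound 2 holds the lower number, at 1530 nM. Compound 3 `COc1ccc(-c2cc3c(cn2)[nH]c(=O)n3-c2cc(OC)c(OC)c(OC)c2)cc1N` has not yet been measured. It differs from compound 2 by amino in place of methyl on an aromatic carbon, ortho to a methoxy group (amino in place of methyl on an aromatic carbon).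

Going by the values given here, only one measured step bears on this change: a 2.8-fold lower number from compound 1 to compound 2 (0.45 log units; beyond the scatter). That step is modest but beyond the scatter. Among the compounds with values here, it also swaps different groups, and no measured compound carries amino, so it offers only a rough guide to size and none to direction. A step of similar size is nevertheless expected in this assay, leaning towards a lower number, though this expectation is weakly supported. The expected change is a 3.8-fold lower number from compound 2 to compound 3 (0.58 log units; beyond the scatter). The wide range below reflects that uncertainty. For compound 3 the estimated value is 400 nM, with an expected range from 40 nM to 2500 nM.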

Compound 3, half-maximal inhibitory concentration: 640 nM
For compound 3 the middle estimate is 1.6-fold (0.20 log units) below the measured one; measured number inside the range.
By their numbers in this assay, from the lowest: compound 3; then compound 2; then compound 1.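

In this assay, amino in place of methyl on an aromatic carbon, ortho to a methoxy group, gives a 2.4-fold lower number from compound 2 to compound 3 (0.38 log units; beyond the scatter), so a change at this one position, with the methoxy group held constant, moves the number beyond the scatter; the earlier step between compound 1 and compound 2 altered both substituents on this ring together and could not show that. Taken over the whole substituted ring, 3-amino-4-methoxyphenyl in place of 4-ethoxy-3-fluorophenyl gives a 6.8-fold lower number from compound 1 to compound 3 (0.83 log units; beyond the scatter), and among these three compounds the lowest number belongs to compound 3, at 640 nM. Nothing available here accounts for the gain seen with amino.

The compounds shown leave open whether the gain with amino would persist if the neighbouring methoxy group gave way to ethoxy, since amino appears only beside methoxy in this set. They also leave open how a hydroxyl group, an acetamide or a dimethylamino group would compare with amino at this position, and whether any such group would bring the number lower than that of compound 3.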